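Trimming the para substituent: isopropyl to methyl

The compounds below may be only part of what the source reports. "The series", "measured", "known", "first", "only" and "open" are said of these compounds alone.

Measured compounds:
- compound 1, `CC(C)c1ccc(-c2nc(SCc3cn(CC(=O)NC(=O)Nc4ccccn4)nn3)nc(Nc3cccc(Cl)c3)c2C#N)cc1`, 18000 nM
- compound 2, `CC(C)c1ccc(-c2nc(SCc3cn(CC(=O)NC(=O)Nc4ccccn4)nn3)nc(Nc3ccccc3F)c2C#N)cc1`, > 64000 nM
- compound 3, `Cc1ccccc1Nc1nc(SCc2cn(CC(=O)NC(=O)Nc3ccccn3)nn2)nc(-c2ccc(C(C)C)cc2)c1C#N`, > 64000 nM

For the measured compounds named here, in a functional assay on MCF7 cells (Homo sapiens) for inhibition, read by MTT assay, with a stated time of 72 h (a lower number here means a stronger inhibitor, a higher number a weaker inhibitor), compound 1 gives 18000 nM, the only plain number among the three values shown. For compound 2 the result is a limit of the assay, > 64000 nM. For compound 3 the result is likewise a limit, > 64000 nM. The two changes on the aniline nitrogen, an at least 3.5-fold higher number from compound 1 to compound 2 (0.55 log units; beyond the scatter) and an at least 3.5-fold higher number from compound 1 to compound 3 (0.55 log units; beyond the scatter), both run toward (the limit of > 64000 nM in this assay, at which 2 of the 3 values shown sit), and the step that the two limits leave unreadable from compound 2 to compound 3 between the two limits cannot be read.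

Compound 4, `Cc1ccc(-c2nc(SCc3cn(CC(=O)NC(=O)Nc4ccccn4)nn3)nc(Nc3cccc(Cl)c3)c2C#N)cc1`, differs from compound 1 at a different place: methyl in place of isopropyl on an aromatic carbon, para to a large group. Going by the values given here, none of the measured steps touches this ring; all of them change the ring on the aromatic nitrogen, so they give no guide to the size or direction of this step. The estimate is therefore anchored on compound 1 alone. The step of a 1.4-fold higher number from compound 1 to compound 4 (0.14 log units; within the scatter) is expected to stay within the scatter. Compound 4 is thus expected to give about 25000 nM in this assay, with a range from 10000 nM to 64000 nM.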

Compound 4, half-maximal inhibitory concentration: 14900 nM
Compound 4: middle estimate off by 1.7-fold (0.22 log units), on the high side, within the range that was stated.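

Cutting the para substituent back from isopropyl to methyl gives, in this assay, a 1.2-fold lower number from compound 1 to compound 4 (0.08 log units; within the scatter), so the two compounds cannot be told apart in this assay. The earlier compounds shown here varied only the ring on the nitrogen, and they said nothing about the 4-isopropylphenyl ring; this pair shows that, with 3-chlorophenyl held in place, the isopropyl group can give way to methyl without a measurable difference. Unlike the compounds that carry the other two rings on the nitrogen, compound 4 also gives a plain number, so this step can be read in full, which is not true of every comparison in the set: the limit of > 64000 nM in this assay, at which 2 of the 4 values shown sit.

Only isopropyl and methyl are shown at this position, so it remains open how a longer chain, an amine or a carboxylic acid there would read. From the compounds shown here alone, it also remains open whether methyl and isopropyl would stay as close with 2-fluorophenyl or 2-methylphenyl on the nitrogen, since the compounds carrying those rings sit at a limit of the assay.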